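Amine for Acid on the Side Chain of Compound 3

This account rests on a few compounds, and the source may have more. Where it says the series, first, only, none or still open, it means among the compounds named here.

Compound 1 `CC(C)(C)OC(=O)NCC1CCCN(C(=O)CN2CN(c3ccccc3)C3(CCN(C(=O)c4ccc(C5CCCCC5)cc4)CC3)C2=O)C1` gives 3800 nM in an assay on HEK293 cells for displacement of a labelled ligand from NPC1-like intracellular cholesterol transporter 1 (Homo sapiens); on this read-out higher numbers stand for weaker inhibition and lower numbers for stronger inhibition.
Compound 2 `COC(=O)CCNC(=O)CN1CN(c2ccccc2)C2(CCN(C(=O)c3ccc(C4CCCCC4)cc3)CC2)C1=O` gives 12900 nM in this assay.
Compound 3 `CC(C)(C)c1ccc(C(=O)N2CCC3(CC2)C(=O)N(CC(=O)NCCC(=O)O)CN3c2ccccc2)cc1` gives 11400 nM in this assay.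

Among the three measured compounds, compound 3 holds the second highest number. Its nearest neighbour is compound 2, whose value sits within the scatter of that of compound 3, so the two cannot be told apart here. Compound 1 stands furthest away, with a number beyond the scatter below that of compound 3.

Compound 4 `CC(C)(C)c1ccc(C(=O)N2CCC3(CC2)C(=O)N(CC(=O)NCCCN)CN3c2ccccc2)cc1` has not yet been measured. It differs from compound 3 in a single place: aminomethyl in place of carboxy on a saturated chain carbon, two bonds along the chain from an amide-type nitrogen. Among the compounds with values here, no step between two measured compounds covers this change, so there is no measured precedent to lean on. In this assay a step of modest size is expected, more likely toward a lower number than a higher one, though a step within the scatter remains quite possible. The expected step from compound 3 to compound 4 is a 1.6-fold lower number from compound 3 to compound 4 (0.21 log units; within the scatter). For compound 4 the estimate is 7000 nM, with a range from 1500 nM to 30000 nM.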

Compound 4, half-maximal inhibitory concentration: 4200 nM
Compound 4: the middle estimate sits 1.7-fold (0.22 log units) above what was measured; low and high end bracket the measured number.
By their numbers in this assay, from the lowest: compounds 1 and 4 (each within the scatter of the next); then compounds 3 and 2 (each within the scatter of the next).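

In this assay, the end of this side chain proves able to move the read-out: aminomethyl in place of carboxy on a saturated chain carbon, two bonds along the chain from an amide-type nitrogen, gives a 2.7-fold lower number from compound 3 to compound 4 (0.43 log units; beyond the scatter). This is the first single-place step among the compounds shown, so the position can now be read directly, and the carboxy group is seen not to be required for the inhibition measured here. Nothing in hand accounts for the size or direction of this step.

The exchange replaces 2-carboxyethyl with 3-aminopropyl, so the compounds shown do not separate the change of end group from the longer chain. A 2-aminoethyl group would address that point, while a hydroxyl or a methyl ester at the end of the same chain would show whether the amine itself matters.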